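Methylphenyl Shift on a Shared Core: Expected Cytotoxicity

The source may report more compounds than this note shows. Statements on the series, on what has been measured and on what is new or still open speak of the compounds shown alone.

compound 1, `Cc1ccc(Nc2nc(C)c(C(=O)/C=C/c3ccc(Cl)cc3)s2)cc1`: > 25000 nM
compound 2, `Cc1ccc(Nc2nc(C)c(C(=O)/C=C/c3ccccc3Cl)s2)cc1`: > 25000 nM

Compound 1 `Cc1ccc(Nc2nc(C)c(C(=O)/C=C/c3ccc(Cl)cc3)s2)cc1` was tested in a functional assay on NCI-H460 cells (Homo sapiens) for cytotoxicity, read by MTT assay; a lower number here means a stronger inhibitor, a higher number a weaker inhibitor. In this assay compound 1 gives > 25000 nM, which is a limit of the assay and not a number. Compound 2 `Cc1ccc(Nc2nc(C)c(C(=O)/C=C/c3ccccc3Cl)s2)cc1` differs from compound 1 by 2-chlorophenyl in place of 4-chlorophenyl on a double-bonded chain carbon bound to a double-bonded chain carbon. In this assay compound 2 gives > 25000 nM, again a limit rather than a number. The step that the two limits leave unreadable from compound 1 to compound 2 therefore cannot be read in size or direction. Among the compounds with values here, the only evidence here is the limit of > 25000 nM in this assay, at which 2 of the 2 values shown sit.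

Compound 3 `Cc1cccc(Nc2nc(C)c(C(=O)/C=C/c3ccc(Cl)cc3)s2)c1` has not yet been measured. It differs from compound 1 by 3-methylphenyl in place of 4-methylphenyl on a nitrogen on an aromatic ring. No measured step touches this part of the shared core, and compound 1 itself stands only at a limit, so no direction can be taken from the numbers shown. With the limit of compound 1 as the only anchor, compound 3 is expected to sit at that same limit, a step that the limit leaves unreadable from compound 1 to compound 3. The estimate for compound 3 is 30000 nM, with a range from 8000 nM to 120000 nM.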

Compound 3, half-maximal inhibitory concentration: > 25000 nM
Compound 3 gave a limit, no number (the forecaster's own chance of this, stated with the estimate: 85%); the middle value lies beyond the limit too.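

In this assay, within the data shown here, compound 3 gives > 25000 nM as a limit of the assay and not a number, so no step between compound 1 and compound 3 can be read in size or direction. The compounds shown leave open how strongly any of them acts in this assay and whether 3-methylphenyl and 4-methylphenyl differ there at all.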